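Swapping the outer aryl ring in a urea antagonist series

A few compounds are considered here, and "the series" means these few. Any claim that something is new, unique, unknown or untested is made for them only; others in the source may bear on it.

Measured compounds:
- compound 1, `Cc1ccc(CN2CCC(NC(=O)NCc3ccc(-c4ccc(F)cc4)cc3)CC2)cc1`: 105%
- compound 2, `COc1ccccc1-c1ccc(CNC(=O)NC2CCN(Cc3ccc(C)cc3)CC2)cc1`: 99.5%

Both were tested in an in vitro functional assay on HEK293 cells for antagonist activity at melanin-concentrating hormone receptor 1 (Homo sapiens); on this read-out lower numbers stand for smaller maximal responses and higher numbers for larger maximal responses. Compound 2 shows the lower of the two numbers, and its nearest neighbour is compound 1, whose value lies close: the step of a number 5.5 percentage points lower from compound 1 to compound 2 (within the scatter) is within the scatter, so the two compounds cannot be told apart on this read-out.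

Compound 3, `Cc1ccc(CN2CCC(NC(=O)NCc3ccc(-c4cccc(C#N)c4)cc3)CC2)cc1`, has not yet been measured. It differs from compound 2 in one place: 3-cyanophenyl in place of 2-methoxyphenyl on an aromatic carbon.

For the measured compounds named here, only one step bears on this change, the step of a number 5.5 percentage points lower from compound 1 to compound 2 (within the scatter), and it lies within the scatter. Nothing here suggests that changing this outer ring shifts the maximal response. The expected step of a number 0.5 percentage points higher from compound 2 to compound 3 (within the scatter) is therefore none beyond the scatter. Compound 3 is estimated to give 100%, within a range from 85% to 115%.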

Compound 3, largest response reached (reported as Imax), in percent of the reference or control that the assay uses: 98%
Estimate against measurement, compound 3: 2 percentage points above, within the range that was stated.
By their numbers in this assay, from the lowest: compounds 3, 2 and 1 (each within the scatter of the next).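

Read in this assay, the swap to 3-cyanophenyl gives a number 1.5 percentage points lower from compound 2 to compound 3 (within the scatter) and, against the fluorinated ring, a number 7 percentage points lower from compound 1 to compound 3 (within the scatter) so all three compounds cannot be told apart. For the compounds shown here, the earlier pair offered only one comparison, whereas this third ring, with its nitrile, shows that the same holds across three different outer rings, each carrying a different group at a different place on the ring. Nothing available accounts for this result at the level of mechanism.

All three outer rings are aromatic rings of carbon with one small neutral group, so the picture covers only that narrow range. On these data alone, whether an aminomethyl group or a carboxylic acid on this ring, or a saturated cyclohexyl ring in its place, would give a different maximal response remains open.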